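Cyclopropylethynyl to 4-fluorophenyl: the step still unmeasured

A few compounds are considered here, and "the series" means these few. Any claim that something is new, unique, unknown or untested is made for them only; others in the source may bear on it.

- compound 1 `Nc1ncnn2c([C@@H]3O[C@H](CO)[C@@H](O)[C@H]3O)cc(C#CC3CC3)c12` gives 30 nM
- compound 2 `Nc1ncnn2c([C@@H]3O[C@H](CO)[C@@H](O)[C@H]3O)cc(C#Cc3ccccc3)c12` gives 88000 nM

In a functional assay on LN-229 cells (Homo sapiens) for antiproliferative activity, with a stated time of 72 h (a lower number here means a stronger inhibitor, a higher number a weaker inhibitor), compound 1 stands lowest of the two numbers at 30 nM and is the reference point here. Compound 3 `Nc1ncnn2c([C@@H]3O[C@H](CO)[C@@H](O)[C@H]3O)cc(-c3ccc(F)cc3)c12` has not yet been measured. The change (4-fluorophenyl in place of 2-cyclopropylethynyl on an aromatic carbon) puts 4-fluorophenyl in place of 2-cyclopropylethynyl on an aromatic carbon. Within the data shown here, one measured step bears on it: phenyl in place of cyclopropyl on a triple-bonded carbon gave a 2900-fold higher number from compound 1 to compound 2 (3.47 log units; beyond the scatter) and was large. That step is only a partial guide, as compound 2 keeps the triple bond and compound 3 does not. In this assay the expected step is a 170-fold higher number from compound 1 to compound 3 (2.22 log units; beyond the scatter) and is thus large, towards a higher number. For compound 3 the estimated value is 5000 nM (expected range 300 nM to 60000 nM).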

Compound 3, half-maximal inhibitory concentration: 65600 nM
Compound 3: the middle estimate sits 13-fold (1.12 log units) below what was measured, outside the stated range (above it).
By their numbers in this assay, from the lowest: compound 1; then compounds 3 and 2 (each within the scatter of the next).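

In this assay, 4-fluorophenyl in place of 2-cyclopropylethynyl on the aromatic carbon gives a 2200-fold higher number from compound 1 to compound 3 (3.34 log units; beyond the scatter) and so is a large step, like the earlier change at the end of the triple bond. Between the two compounds carrying a six-membered aromatic ring, the step is a 1.3-fold lower number from compound 2 to compound 3 (0.13 log units; within the scatter) and lies within the scatter: with such a ring at this position, the presence or absence of the triple bond makes no readable difference, and of the three compounds only compound 1 gives a low number. Nothing available here gives a reason for this pattern.

On these data alone, whether the low number belongs to the cyclopropyl ring alone stays open: a methyl, tert-butyl or cyclobutyl group on the triple bond would test that. Also open, as far as these compounds go, is how a cyclopropyl group on the aromatic carbon, without the triple bond, would compare with compound 1.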